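A Pyrazinyl Ring Replaces a Methoxyphenyl Group

This account rests on a few compounds, and the source may have more. Where it says the series, first, only, none or still open, it means among the compounds named here.

Three compounds share one core and differ only in the group attached to the thiocarbonyl carbon. In a functional assay on MGC-803 cells (Homo sapiens) for antiproliferative activity, read by CCK-8 assay, with a stated time of 72 h, tested at 2 uM (on this read-out higher numbers stand for a stronger effect at the one concentration tested and lower numbers for a weaker effect), compound 1 `CC1CCN(C(=S)SCc2ccc(C(=O)Nc3ccccc3N)cc2)CC1` gives 28.1%, compound 2 `CN(Cc1cccnc1)C(=S)SCc1ccc(C(=O)Nc2ccccc2N)cc1` gives 45.9%, and compound 3 `COc1ccc(N2CCN(C(=S)SCc3ccc(C(=O)Nc4ccccc4N)cc3)CC2)cc1` gives 25.3%, the lowest of the three numbers, though its gap to compound 1 lies within the scatter; the only gap beyond the scatter is a number 17.8 percentage points higher from compound 1 to compound 2 (beyond the scatter). Compound 4 `Nc1ccccc1NC(=O)c1ccc(CSC(=S)N2CCN(c3cnccn3)CC2)cc1` differs from compound 3 by pyrazin-2-yl in place of 4-methoxyphenyl on an amine nitrogen in a ring. Among the measured compounds shown here, the single measured step changes the group on the thiocarbonyl carbon, not the amine nitrogen in the ring, so no measured step bears on this change. No shift beyond the scatter is therefore expected, and compound 4 is estimated at 27%, between 12% and 45%. For compound 4 this means an expected step of a number 1.7 percentage points higher from compound 3 to compound 4 (within the scatter).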

Compound 4, a percentage reported as inhibition, at one concentration (the size of the read-out at that concentration, not a potency): 27.1%
The estimate for compound 4 lay 0.1 percentage points below the measured number, within the range that was stated.
By their numbers in this assay, from the lowest: compounds 3, 4 and 1 (each within the scatter of the next); then compound 2.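

In this assay, pyrazin-2-yl in place of 4-methoxyphenyl on the amine nitrogen in the ring gives a number 1.8 percentage points higher from compound 3 to compound 4 (within the scatter). This is the first change shown at this position: a six-membered aromatic ring of carbon only gives way to one with 2 hetero atoms, and the number stays within the scatter. No measurement here offers an explanation for this result. On these data alone, whether a methyl group or an acetyl group on this nitrogen would move the number beyond the scatter remains open.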